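Removing one methyl from compound 2: working notes

The source may hold more compounds than are shown below. What is called first, only, known or untested is meant among the compounds shown, and "the series" means these compounds.

Measured in a functional assay on PC-3 cells (Homo sapiens); on this read-out lower numbers stand for stronger inhibition of growth and higher numbers for weaker inhibition of growth:
- compound 1 `COc1ccc(-c2cc(O)c3cccnc3n2)cc1`: 31600 nM
- compound 2 `COc1ccc(-c2cc(O)c3c(C)cc(C)nc3n2)cc1`: 24000 nM

Compound 2 stands level with compound 1, within the scatter. Compound 3 `COc1ccc(-c2cc(O)c3ccc(C)nc3n2)cc1` awaits measurement and carries hydrogen in place of methyl on an aromatic carbon, opposite the ring nitrogen (hydrogen in place of methyl on an aromatic carbon). Among the measured compounds shown here, no single-change step between measured compounds exists. Compound 1 lacks both methyl groups, yet compound 1 at 31600 nM and compound 2 at 24000 nM do not separate. No step beyond the scatter is therefore expected in this assay. The expected step is a 1.1-fold higher number from compound 2 to compound 3 (0.05 log units; within the scatter). For compound 3 the estimated value is 27000 nM, with an expected range of 12000 nM to 60000 nM.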

Compound 3, concentration for 50% growth inhibition: > 100000 nM
Compound 3 was reported as a limit (the forecaster's own chance of this, stated with the estimate: 15%); at least 3.7-fold (0.56 log units) between middle value and limit.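

In this assay, among the compounds shown here, this aromatic carbon opposite the ring nitrogen proves sensitive, which no earlier single-change step could show: hydrogen in place of methyl gives an at least 4.1-fold higher number from compound 2 to compound 3 (0.61 log units; beyond the scatter). Compound 3 is also separated from its other neighbour, with methyl in place of hydrogen on an aromatic carbon giving an at least 3.1-fold higher number from compound 1 to compound 3 (0.50 log units; beyond the scatter). The value of compound 3 is a limit, not a number: the limit of > 100000 nM in this assay, at which 1 of the 3 values shown sits.

On these data alone, the true size of both steps remains open. So does whether an ethyl group or an amine on this carbon would stay level with compound 2.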